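Ethoxycarbonyl to hydroxymethyl on the core of compound 1

The compounds below may be only part of what the source reports. "The series", "measured", "known", "first", "only" and "open" are said of these compounds alone.

Measured so far in a functional assay on Rec1 cells (Homo sapiens) for inhibition, read by luminescence and CellTiter-Glo, with a stated time of 72 h; a higher number here means a weaker inhibitor, a lower number a stronger inhibitor
- compound 1 (`C/C=C/C(=O)N1CCCC(n2nc(-c3ccc(Oc4ccccc4)cc3)cc2C(=O)OCC)C1`): 5100 nM
- compound 2 (`C=CC(=O)N1CCCC(n2nc(-c3ccc(Oc4ccccc4)cc3)cc2C(=O)OCC)C1`): 13800 nM
- compound 3 (`CCOC(=O)c1cc(-c2ccc(Oc3ccccc3)cc2)nn1C1CCCN(C(=O)CCl)C1`): 400 nM

Compound 1 holds the middle of the three numbers, with (a 2.7-fold higher number from compound 1 to compound 2 (0.43 log units; beyond the scatter)) on one side and (a 13-fold lower number from compound 1 to compound 3 (1.11 log units; beyond the scatter)) on the other. Compound 4 (`C/C=C/C(=O)N1CCCC(n2nc(-c3ccc(Oc4ccccc4)cc3)cc2CO)C1`) keeps the prop-1-en-1-yl on the carbonyl carbon of compound 1 and carries hydroxymethyl in place of ethoxycarbonyl (hydroxymethyl in place of ethoxycarbonyl on an aromatic carbon). The third measured step is (a 35-fold lower number from compound 2 to compound 3 (1.54 log units; beyond the scatter)). All three steps, modest to large, change only the group on the carbonyl carbon. Within the data shown here, no measured compound varies the ethoxycarbonyl, so these steps show that the numbers can move but give neither size nor direction for this change. No step beyond the scatter is therefore expected in (this assay), with wide uncertainty on both sides. The expected step is (a 1.2-fold higher number from compound 1 to compound 4 (0.07 log units; within the scatter)). Compound 4 is estimated at (6000 nM), with an expected range of (1500 nM) to (24000 nM).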

Compound 4, half-maximal inhibitory concentration: 27200 nM
Estimate against measurement, compound 4: 4.5-fold (0.66 log units) below; the measured number lies above the stated range.
By their numbers in this assay, from the lowest: compound 3; then compound 1; then compounds 2 and 4 (each within the scatter of the next).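

The position bearing the ethoxycarbonyl on the core of compound 1 does affect the read-out in this assay: hydroxymethyl in its place gives a weaker inhibitor (a 5.3-fold higher number from compound 1 to compound 4 (0.73 log units; beyond the scatter)). Among these compounds, this is the first measured step that leaves the group on the carbonyl carbon unchanged, so that group is not the only place where the numbers move. Hydroxymethyl is therefore not a neutral replacement for ethoxycarbonyl on this background, and nothing available accounts for the loss.

A single replacement cannot separate the shorter group from the change from ester to alcohol, and a carboxylic acid, a primary amide or a longer ester at this place would help to tell these apart. Also open, from the compounds shown here alone, is whether the same replacement costs as much with chloromethyl on the carbonyl carbon, as in compound 3.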